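Three Weak Quinazoline-Type Analogues and a Chlorophenyl Replacement

The source may hold more compounds than are shown below. What is called first, only, known or untested is meant among the compounds shown, and "the series" means these compounds.

Compound 3 `Fc1cccc(-c2nc(Nc3ccccc3F)c3cc(F)ccc3n2)c1` reaches only a limit in a functional assay on U2OS cells (Homo sapiens) for cytotoxicity, read by MTT assay, with a stated time of 48 h (on this read-out lower numbers stand for stronger inhibition and higher numbers for weaker inhibition), > 50000 nM, and so stands at the limit of > 50000 nM in this assay, at which 2 of the 3 values shown sit. Compound 1 `Fc1cccc(-c2nc(Nc3ccccc3)c3cc(F)ccc3n2)c1` gives 47600 nM in this assay. Compound 2 `Fc1ccc(Nc2nc(-c3cccc(F)c3)nc3ccc(F)cc23)cc1` likewise returns only a limit in this assay, > 50000 nM. Compound 4 `Fc1cccc(-c2nc(Nc3ccc(Cl)cc3)c3cc(F)ccc3n2)c1` carries 4-chlorophenyl in place of 2-fluorophenyl on a nitrogen on an aromatic ring; cut one bond further out, this reads (2-fluorophenyl)amino to (4-chlorophenyl)amino. The measured steps that bear on it are an at least 1.0-fold higher number from compound 1 to compound 2 (0.02 log units; that floor lies within the scatter) and an at least 1.0-fold higher number from compound 1 to compound 3 (0.02 log units; that floor lies within the scatter), each with a floor inside the scatter, while a step that the two limits leave unreadable from compound 2 to compound 3. Nothing among these three compounds points to a step beyond the scatter, so compound 4 is expected to stay near the limit, a number no higher from compound 3 to compound 4 (the limit leaves the size open). The estimate for compound 4 is 50000 nM, expected between 20000 nM and 120000 nM.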

Compound 4, half-maximal inhibitory concentration: 38400 nM
For compound 4 the middle estimate is 1.3-fold (0.11 log units) above the measured one, and the stated range covers the measured number.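

With 4-chlorophenyl on the nitrogen, compound 4 gives a readable number in this assay while compound 2 and compound 3 remain limits: (the limit of > 50000 nM in this assay, at which 2 of the 4 values shown sit). The steps read an at least 1.3-fold lower number from compound 3 to compound 4 (0.11 log units; that floor lies within the scatter) and also an at least 1.3-fold lower number from compound 2 to compound 4 (0.11 log units; that floor lies within the scatter) with neither floor beyond the scatter. Chloro in place of hydrogen gives a 1.2-fold lower number from compound 1 to compound 4 (0.09 log units; within the scatter) and so no difference that stands out. From the compounds shown here alone, whether a methoxy group or a carboxylic acid on that phenyl ring would bring a step beyond the scatter stays open, as does how far compound 2 and compound 3 lie past their limits.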